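Sulfonyl-to-carboxamide swap on the fused-ring substituent

A few compounds are considered here, and "the series" means these few. Any claim that something is new, unique, unknown or untested is made for them only; others in the source may bear on it.

Compound 1 `CC#C[C@@H](CC(=O)O)c1ccc(OC[C@H]2COc3ccc(OC)cc3O2)cc1`: in a functional assay on HEK293 cells for agonist activity at Free fatty acid receptor 1 (Homo sapiens), read by fluorescence and calcium flux, with a stated time of 10 min (on this read-out lower numbers stand for smaller maximal responses and higher numbers for larger maximal responses), compound 1 gives 91%.
Compound 2 `CC#C[C@@H](CC(=O)O)c1ccc(OC[C@H]2COc3ccc(S(C)(=O)=O)cc3O2)cc1`: in this assay compound 2 gives 55%.

For the measured compounds named here, compound 2 carries the lower of the two maximal responses recorded so far; the single measured step, a number 36 percentage points lower from compound 1 to compound 2 (beyond the scatter), separates it from compound 1.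

Compound 3 `CC#C[C@@H](CC(=O)O)c1ccc(OC[C@H]2COc3ccc(C(=O)N(C)C)cc3O2)cc1` differs from compound 2 in one place: dimethylcarbamoyl in place of methylsulfonyl on an aromatic carbon.

Going by the values given here, only one step has been measured, and it concerns a different exchange, methylsulfonyl in place of methoxy, with the large drop noted above. Among the compounds with values here, no measured pair speaks to dimethylcarbamoyl against methylsulfonyl on that aromatic carbon, so the data give no direct guide. Within the data shown here, since the one known exchange at this position moved the response strongly, a substantial move in either direction cannot be excluded, but nothing points to one. The expected step is therefore small, a number 7 percentage points higher from compound 2 to compound 3 (within the scatter), in this assay. Compound 3 is estimated at 62%, with a range from 40% to 88%.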

Compound 3, largest response reached (Emax), in percent of the reference or control that the assay uses: 32%
Compound 3: middle estimate off by 30 percentage points, on the high side; measured number outside the range, below it.
By their numbers in this assay, from the lowest: compound 3; then compound 2; then compound 1.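

In this assay, dimethylcarbamoyl in place of methylsulfonyl on the aromatic carbon gives a number 23 percentage points lower from compound 2 to compound 3 (beyond the scatter), so the maximal response at this position differs beyond the scatter even between two replacements of methoxy. Measured against methoxy, the change is larger, with a number 59 percentage points lower from compound 1 to compound 3 (beyond the scatter), and among these three compounds the order runs from methoxy at the top, through methylsulfonyl, to dimethylcarbamoyl at the bottom. The series offers no evidence on why the groups fall in this order.

Still open, going by these compounds, is whether a fluorine, an ethoxy group or a primary carboxamide on this aromatic carbon would keep the response close to that of compound 1 or leave it with compound 2 and compound 3. Also open, on these data alone, is whether the same order of methoxy, methylsulfonyl and dimethylcarbamoyl would hold with a tetrazole in place of the carboxylic acid of the shared core.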